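Removing the trifluoromethyl from compound 3

This account rests on a few compounds, and the source may have more. Where it says the series, first, only, none or still open, it means among the compounds named here.

Of the compounds shown here, three sharing one core have been measured: compound 1 `Cc1ccc(-c2nc3sccn3c2/C=N/OCc2ccc(Cl)c(Cl)c2)cc1`, compound 2 `Clc1ccc(CO/N=C/c2c(-c3ccc(Br)cc3)nc3sccn23)cc1Cl` and compound 3 `FC(F)(F)c1ccc(-c2nc3sccn3c2/C=N/OCc2ccc(Cl)c(Cl)c2)cc1`. In an assay on HepG2 cells for agonist activity at nuclear receptor subfamily 1 group I member 3 (Homo sapiens), read by a luciferase reporter, with a stated time of 23 h (on this read-out lower numbers stand for an effect already at smaller amounts and higher numbers for an effect only at larger amounts of compound), compound 1 gives 490 nM, compound 2 gives 480 nM and compound 3 gives 880 nM, so compound 3 stands highest of the three, though its steps to both neighbours lie within the scatter. The next compound, compound 4 `Clc1ccc(CO/N=C/c2c(-c3ccccc3)nc3sccn23)cc1Cl`, differs from compound 3 only by hydrogen in place of trifluoromethyl on an aromatic carbon. Among the measured compounds shown here, the steps that bear on this change are a 1.8-fold higher number from compound 1 to compound 3 (0.25 log units; within the scatter) and a 1.8-fold higher number from compound 2 to compound 3 (0.26 log units; within the scatter), both small, showing the group on that aromatic carbon matters little here. Compound 4 is therefore expected to move by a 1.6-fold lower number from compound 3 to compound 4 (0.20 log units; within the scatter), a step not beyond the scatter, with an estimated value of 550 nM in this assay, between 220 nM and 1400 nM.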

Compound 4, half-maximal effective concentration: 580 nM
Beside the measured number, compound 4's estimate is 1.1-fold (0.02 log units) below it, and the stated range covers the measured number.
By their numbers in this assay, from the lowest: compounds 2, 1, 4 and 3 (each within the scatter of the next).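

With hydrogen, this aromatic carbon carries no group at all, and in this assay the steps are still small: a 1.5-fold lower number from compound 3 to compound 4 (0.18 log units; within the scatter), a 1.2-fold higher number from compound 2 to compound 4 (0.08 log units; within the scatter) and a 1.2-fold higher number from compound 1 to compound 4 (0.07 log units; within the scatter). Methyl, bromo, trifluoromethyl and hydrogen at this place therefore cannot be told apart in this read-out, so the 4-(trifluoromethyl)phenyl to phenyl change has no effect that can be resolved here. No supporting evidence accompanies these numbers to explain this. From the compounds shown here alone, whether an amine or a carboxylic acid on this carbon would also stay within the scatter remains open, as does whether a change elsewhere on the shared core would give a larger step.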